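Trading an ethoxyphenyl for an ethylphenyl on the amide

The source may hold more compounds than are shown below. What is called first, only, known or untested is meant among the compounds shown, and "the series" means these compounds.

Compound 1 `CCOc1ccc(NC(=O)c2cccc(/C=C3\CC(=O)N(c4ccccc4)C3=O)c2)cc1`: in an ADME assay on NCM460 cells (Homo sapiens) for cytotoxicity, read by MTT assay, with a stated time of 72 h (a lower number here means a stronger inhibitor, a higher number a weaker inhibitor), compound 1 reaches only the assay's limit, > 100000 nM.
Compound 2 `CCCCCN1C(=O)C/C(=C\c2cccc(C(=O)Nc3cccc(F)c3)c2)C1=O`: in this assay compound 2 likewise reaches only the limit, > 100000 nM.
Compound 3 `CCCCCN1C(=O)C/C(=C\c2cccc(C(=O)NCCCC)c2)C1=O`: in this assay compound 3 also reaches only the limit, > 100000 nM.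

All three compounds share a core and differ in the group on the amide-type nitrogen and in the group on the ring nitrogen of that core. Compound 1 stands at the limit, and the two further values shown are limits as well, so none of the three can be ranked against another. Going by the values given here, the only measured step, a step that the two limits leave unreadable from compound 2 to compound 3, cannot be read because the limit of > 100000 nM in this assay, at which 3 of the 3 values shown sit, holds both of its ends. That step concerns a different exchange on the amide-type nitrogen, so it offers no measured size that bears on the change now at hand.

Compound 4 `CCc1cccc(NC(=O)c2cccc(/C=C3\CC(=O)N(c4ccccc4)C3=O)c2)c1` differs from compound 1 in one place: 3-ethylphenyl in place of 4-ethoxyphenyl on an amide-type nitrogen. With every value shown sitting at the limit, the expectation is that compound 4 stays there too, with no step beyond the scatter. The expected step is a step that the limit leaves unreadable from compound 1 to compound 4. Compound 4 is thus estimated at 150000 nM, within a range of 50000 nM to 500000 nM, most likely reported again only as a limit.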

Compound 4, half-maximal inhibitory concentration: > 100000 nM
Compound 4: no number, only a limit; the forecaster's own chance of this, stated with the estimate: 85%; the middle value is on the limit's open side.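

In this assay compound 4 gives > 100000 nM, which is a limit of the assay and not a number. The step between compound 1 and compound 4 cannot be read, because both ends sit at the same limit: the limit of > 100000 nM in this assay, at which 4 of the 4 values shown sit.

The compounds shown leave open what size of value, if any, a change in the group on the amide-type nitrogen produces in this assay.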